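A few compounds are considered here, and "the series" means these few. Any claim that something is new, unique, unknown or untested is made for them only; others in the source may bear on it.

Series notes, oxime and ketone analogues in a functional assay on RAW264.7 cells (Mus musculus) for inhibition, read by Griess assay, with stated times of 2 h and 24 h; a higher number here means a weaker inhibitor, a lower number a stronger inhibitor.

Compound 1 `COc1ccc([C@@H]2C/C(=N\O)c3c(O)cc(OCc4cn(CC5CC5)nn4)cc3O2)cc1O` is the reference. In this assay, for the measured compounds named here, compound 1 gives 6320 nM, the lowest number of the three measured so far, and therefore the strongest inhibitor on this set. Compound 2 `CCn1cc(COc2cc(O)c3c(c2)O[C@H](c2ccc(OC)c(O)c2)CC3=O)nn1` gives 15000 nM in this assay, and compound 3 `COc1ccc([C@@H]2CC(=O)c3c(O)cc(OCc4cn(Cc5ccc(F)cc5)nn4)cc3O2)cc1O` gives 15100 nM; both of those numbers sit well away from the number of compound 1, and the two of them are not separated from each other.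

The step from compound 1 to compound 4 `COc1ccc([C@@H]2C/C(=N\O)c3c(O)cc(OCc4cn(Cc5ccccc5F)nn4)cc3O2)cc1O` changes the group on a saturated chain carbon bound to an aromatic nitrogen: 2-fluorophenyl in place of cyclopropyl on a saturated chain carbon bound to an aromatic nitrogen. Going by the values given here, the only measured step at that same carbon is a 1.0-fold higher number from compound 2 to compound 3 (0.00 log units; within the scatter), a swap of methyl for a fluorinated benzyl group that left the number unchanged. A swap of cyclopropyl for a fluorinated phenyl at the same place is therefore expected to behave similarly, with no step beyond the scatter. The expected step is a 1.0-fold higher number from compound 1 to compound 4 (0.01 log units; within the scatter). For compound 4 the estimate in this assay is 6500 nM, within 3000 nM to 14000 nM.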

Compound 4, half-maximal inhibitory concentration: 5710 nM
Compound 4: the middle estimate sits 1.1-fold (0.06 log units) above what was measured; low and high end bracket the measured number.
By their numbers in this assay, from the lowest: compounds 4 and 1 (each within the scatter of the next); then compounds 2 and 3 (each within the scatter of the next).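

In this assay the change reads a 1.1-fold lower number from compound 1 to compound 4 (0.04 log units; within the scatter) and so replacing cyclopropyl with 2-fluorophenyl on a saturated chain carbon bound to an aromatic nitrogen leaves the number unmoved in an oxime compound. For the compounds shown here, the only earlier step at this carbon, a 1.0-fold higher number from compound 2 to compound 3 (0.00 log units; within the scatter), came from ketone compounds, so a flat result at this place now appears with both the oxime and the ketone. Across these two steps, this carbon accepts a fluorinated phenyl group with no change beyond the scatter.

From the compounds shown here alone, whether an amine, a carboxylic acid or a longer chain at this carbon would move the number remains open. What the oxime itself contributes also remains open, as the oxime and ketone compounds shown carry different groups at this carbon. No supporting evidence bears on this result.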